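Inverting One Stereocentre in a Hydroxy Enamide Ester

The compounds below may be only part of what the source reports. "The series", "measured", "known", "first", "only" and "open" are said of these compounds alone.

Measured so far:
compound 1, `CC(C)(C)OC(=O)/C=C\NC(=O)[C@@H](O)C(C)(C)CO`: -11%
compound 2, `COC(=O)/C=C\NC(=O)[C@@H](O)C(C)(C)CO`: -12%

Among the measured compounds shown here, in an ADME assay on HEK293 cells (Homo sapiens) for inhibition, read by CellTiter-Glo, with a stated time of 96 h, tested at 100 uM (on this read-out higher numbers stand for more inhibition at the one concentration tested (going by the name of the read-out) and lower numbers for less inhibition), compound 1 gives -11%, the higher of the two numbers, though the only measured step, a number 1 percentage points lower from compound 1 to compound 2 (within the scatter), lies within the scatter. Compound 3, `CC(C)(C)OC(=O)/C=C\NC(=O)[C@H](O)C(C)(C)CO`, differs from compound 1 only in that (the two compounds have the same atoms and bonds and differ only in configuration as drawn: 1 of 2 stereo elements differ; a stereocentre at a saturated chain carbon is drawn S in compound 1 and R in compound 3). For the measured compounds named here, no measured step bears on a change of configuration; the single step concerns a different part of the molecule and was itself within the scatter. With nothing in the data to suggest otherwise, a step of no change at the digits printed from compound 1 to compound 3 (within the scatter) is expected, that is, none beyond the scatter. Compound 3 is therefore estimated at -11%, between -26% and 4%.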

Compound 3, a percentage reported as inhibition, at one concentration (the size of the read-out at that concentration, not a potency): -9%
Compound 3: the middle estimate sits 2 percentage points below what was measured; the range from low to high includes it.
By their numbers in this assay, from the lowest: compounds 2, 1 and 3 (each within the scatter of the next).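

In this assay, among the compounds shown here, inverting the stereocentre at the saturated chain carbon gives a number 2 percentage points higher from compound 1 to compound 3 (within the scatter), the first reading of a change at this position rather than at the ester. Whatever separates these two numbers can lie only in the stereocentre: the fact that compounds 1 and 3 differ only in the configuration as drawn. At this one concentration, then, the configuration drawn at this carbon shows no effect beyond the scatter in the tert-butyl ester series. The compounds shown leave open whether the same inversion reads alike in the methyl ester, compound 2. They also leave open whether an amine on that carbon, or a carboxylic acid in place of the ester, would shift the number.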